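This account rests on a few compounds, and the source may have more. Where it says the series, first, only, none or still open, it means among the compounds named here.

Measured compounds in a functional assay on HT-29 cells (Homo sapiens) for cytotoxicity, read by MTT assay, with a stated time of 72 h; on this read-out lower numbers stand for stronger inhibition and higher numbers for weaker inhibition:

Compound 1, `CN(C)CCn1cnnc1-c1cc(Oc2ccc(NC(=O)N/N=C/c3ccc(F)cc3)cc2F)ccn1`: 1370 nM
Compound 2, `COc1cc(/C=N/NC(=O)Nc2ccc(Oc3ccnc(-c4nncn4CCN(C)C)c3)c(F)c2)cc(OC)c1OC`: 3620 nM
Compound 3, `CN(C)CCn1cnnc1-c1cc(Oc2ccc(NC(=O)N/N=C/c3ccc(O)c(O)c3)cc2F)ccn1`: 1890 nM

All three share one core and differ only in the aromatic ring attached to the carbon with a double bond to nitrogen. Among the three numbers, compound 3 stands second highest. Its steps to the other two both lie within the scatter: a 1.4-fold higher number from compound 1 to compound 3 (0.14 log units; within the scatter) and a 1.9-fold lower number from compound 2 to compound 3 (0.28 log units; within the scatter). For the measured compounds named here, the only step that reaches beyond the scatter is a 2.6-fold higher number from compound 1 to compound 2 (0.42 log units; beyond the scatter), and it is modest.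

Compound 4, `CN(C)CCn1cnnc1-c1cc(Oc2ccc(NC(=O)N/N=C/c3cccc(Cl)c3Cl)cc2F)ccn1`, has not yet been measured. It differs from compound 3 in one place: 2,3-dichlorophenyl in place of 3,4-dihydroxyphenyl on a carbon with a double bond to nitrogen. Compound 1 already shows that a halogen-bearing ring at this position gives a number close to that of compound 3, and compound 2 shows that a heavily substituted ring moves the number only modestly. On that basis no step beyond the scatter is expected, with perhaps a slight lean toward a lower number, as a 1.3-fold lower number from compound 3 to compound 4 (0.10 log units; within the scatter) is the estimate. Compound 4 is therefore expected to give about 1500 nM, with a likely range from 600 nM to 4000 nM.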

Compound 4, half-maximal inhibitory concentration: 130 nM
Compound 4: middle estimate off by 12-fold (1.06 log units), on the high side, and the stated range ends above it.
By their numbers in this assay, from the lowest: compound 4; then compounds 1, 3 and 2 (each within the scatter of the next, the first and the last beyond it).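

In this assay, for the compounds shown here, the aromatic ring on the carbon with a double bond to nitrogen turns out to matter far more than the earlier compounds suggested, since 2,3-dichlorophenyl gives a 15-fold lower number from compound 3 to compound 4 (1.16 log units; beyond the scatter) and a 28-fold lower number from compound 2 to compound 4 (1.44 log units; beyond the scatter), which makes compound 4 the most potent of the four. A halogen on this ring is not enough on its own, as the 4-fluorophenyl ring of compound 1 also carries one and the change still gives an 11-fold lower number from compound 1 to compound 4 (1.02 log units; beyond the scatter). The replacement of 3,4-dihydroxyphenyl also takes the count of hydrogen-bond donors on this ring from 2 to 0, but nothing measured here explains why this ring stands so far apart from the others.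

With only one chlorine-bearing ring in the set, the compounds shown cannot tell whether both chlorine atoms are needed or whether their placement on the ring matters. They also leave open how this position would respond to other groups on the ring, such as bromine, methyl, trifluoromethyl or an amine, and whether the gain would carry over to cells other than the HT-29 line.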